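Dropping the iodo from compound 2: an estimate

The source may hold more compounds than are shown below. What is called first, only, known or untested is meant among the compounds shown, and "the series" means these compounds.

Measured so far:
compound 1 `O=C1C(=O)N(CCCCn2cc(COc3cc(=O)oc4ccccc34)nn2)c2ccc(Cl)cc21` — 60%
compound 2 `O=C1C(=O)N(CCCn2cc(COc3cc(=O)oc4ccccc34)nn2)c2ccc(I)cc21` — 56%

In a functional assay on COLO 205 cells (Homo sapiens) for inhibition, read by sulforhodamine B assay, with a stated time of 48 h, tested at 50 uM (a lower number here means less inhibition of growth, a higher number more inhibition of growth at the concentration tested), compound 1 gives 60%. In this assay compound 2 gives 56%, and it sits alongside compound 1, the two numbers within the scatter of each other. Compound 3 `O=C1C(=O)N(CCCn2cc(COc3cc(=O)oc4ccccc34)nn2)c2ccccc21` has not yet been measured; it differs from compound 2 by hydrogen in place of iodo on an aromatic carbon. Among the measured compounds shown here, no step between measured compounds bears on this change, so the expected step is estimated as small and downward, a number 10 percentage points lower from compound 2 to compound 3 (within the scatter), possibly not beyond the scatter. Compound 3 is expected to give 46%, with a range from 25% to 65%.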

Compound 3, percent growth inhibition at one concentration: 75%
Estimate against measurement, compound 3: 29 percentage points below, outside the stated range (above it).
By their numbers in this assay, from the lowest: compounds 2 and 1 (each within the scatter of the next); then compound 3.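

In this assay the reading comes out a number 19 percentage points higher from compound 2 to compound 3 (beyond the scatter) when hydrogen replaces iodo on this aromatic carbon. The iodo is therefore not needed at this position for growth inhibition at the concentration tested, and of the two groups, hydrogen gives the higher number. Nothing at hand explains this step.

From the compounds shown here alone, whether the step is particular to iodo stays open, since a fluoro, a methoxy or an amine on the same carbon could tell. Going by these compounds, it is also open whether hydrogen in place of chloro would give a similar step in compound 1, which has the longer chain.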